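Shortening one ethyl group on the diethylamino compound

A few compounds are considered here, and "the series" means these few. Any claim that something is new, unique, unknown or untested is made for them only; others in the source may bear on it.

Compound 1 `N=C(NC(=N)NC1CCCC1)Nc1ccc(C(F)(F)F)cc1`: 2500 nM
Compound 2 `CC(C)CNC(=N)NC(=N)Nc1ccc(C(F)(F)F)cc1`: 2100 nM
Compound 3 `CCN(CC)C(=N)NC(=N)Nc1ccc(C(F)(F)F)cc1`: 3800 nM

All three values come from a functional assay on A2780 cells (Homo sapiens) for antiproliferative activity, read by MTT assay, with a stated time of 72 h; on this read-out higher numbers stand for weaker inhibition and lower numbers for stronger inhibition. The compounds share one core and differ only in the group on the amine nitrogen at one end. Compound 3, which carries diethylamino, does not separate from the other two on these numbers. The measured steps to it are a 1.5-fold higher number from compound 1 to compound 3 (0.18 log units; within the scatter) and a 1.8-fold higher number from compound 2 to compound 3 (0.26 log units; within the scatter).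

Compound 4 `CCN(C)C(=N)NC(=N)Nc1ccc(C(F)(F)F)cc1` is the next structure to be tested. The change from compound 3 is hydrogen in place of methyl on a saturated chain carbon bound to an amine nitrogen. The same difference reads as diethylamino to ethyl(methyl)amino.

Among the measured compounds shown here, no measured pair shows this exact change, so the evidence is indirect. The nearest evidence comes from changes at the same amine nitrogen, and these are far larger in structure. Even so, they gave only a 1.5-fold higher number from compound 1 to compound 3 (0.18 log units; within the scatter), a 1.8-fold higher number from compound 2 to compound 3 (0.26 log units; within the scatter) and a 1.2-fold lower number from compound 1 to compound 2 (0.08 log units; within the scatter). A smaller edit is therefore not expected to move the value beyond the scatter in either direction. The estimated step is a 1.3-fold lower number from compound 3 to compound 4 (0.10 log units; within the scatter). Compound 4 is expected at 3000 nM, with an estimated range of 1600 nM to 5500 nM.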

Compound 4, half-maximal inhibitory concentration: 5100 nM
Beside the measured number, compound 4's estimate is 1.7-fold (0.23 log units) below it; measured number inside the range.
By their numbers in this assay, from the lowest: compounds 2, 1, 3 and 4 (each within the scatter of the next, the first and the last beyond it).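

In this assay, among the compounds shown here, the edit from diethylamino to ethyl(methyl)amino gives a 1.3-fold higher number from compound 3 to compound 4 (0.13 log units; within the scatter) and so does not separate the two compounds, which makes this the first direct reading of a change on a saturated chain carbon bound to an amine nitrogen. For the compounds shown here, what the earlier compounds did not show is any separation among the groups at this end of the shared core, and ethyl(methyl)amino now supplies it, with a 2.4-fold higher number from compound 2 to compound 4 (0.39 log units; beyond the scatter) and a 2.0-fold higher number from compound 1 to compound 4 (0.31 log units; beyond the scatter) both printed as modest steps beyond the scatter, although compound 3 remains within the scatter of compound 1, compound 2 and compound 4 alike. No independent measurement is available to account for these steps.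

From the compounds shown here alone, whether dimethylamino, an unsubstituted amine or a longer chain such as n-propyl at this nitrogen would extend the separation or close it remains open. Going by these compounds, it is equally open whether these small steps would persist if a chlorine or a nitrile stood in place of trifluoromethyl on the shared core.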